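Ring size on the shared core: compound 3 to compound 4

This account rests on a few compounds, and the source may have more. Where it says the series, first, only, none or still open, it means among the compounds named here.

Compound 1 `Cc1ccc2c(NCc3ccc(NC(=O)C4CCN(Cc5ccccc5)CC4)cc3)nc(N3CCC(N4CCCC4)CC3)nc2c1` carries 4-(pyrrolidin-1-yl)piperidin-1-yl on the shared core. In a functional assay on SV5A8 cells (Homo sapiens) for cytotoxicity (on this read-out higher numbers stand for weaker inhibition and lower numbers for stronger inhibition), compound 1 reaches only a limit, > 8090 nM. Compound 2 `CCNc1nc(NCc2ccc(NC(=O)C3CCN(Cc4ccccc4)CC3)cc2)c2ccc(C)cc2n1` carries ethylamino on the same carbon; in this assay compound 2 likewise gives only a limit, > 2140 nM. Compound 3 `Cc1ccc2c(NCc3ccc(NC(=O)C4CCN(Cc5ccccc5)CC4)cc3)nc(N3CCC3)nc2c1` carries azetidin-1-yl; in this assay compound 3 again gives only a limit, > 8500 nM. Where compound 3 stands among the three values cannot be fixed: each value is a limit (the limit of > 2140 nM in this assay, at which 1 of the 3 values shown sits, (the limit of > 8090 nM in this assay, at which 1 of the 3 values shown sits), (the limit of > 8500 nM in this assay, at which 1 of the 3 values shown sits)), so none is ordered against another. The steps a step that the two limits leave unreadable from compound 1 to compound 2, a step that the two limits leave unreadable from compound 1 to compound 3 and a step that the two limits leave unreadable from compound 2 to compound 3 are all unreadable for the same reason.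

Compound 4 `Cc1ccc2c(NCc3ccc(NC(=O)C4CCN(Cc5ccccc5)CC4)cc3)nc(N3CCCC3)nc2c1` differs from compound 3 as follows: pyrrolidin-1-yl in place of azetidin-1-yl on an aromatic carbon. Among the measured compounds shown here, no measured step shows what exchanging one small saturated ring for another on this carbon does in this assay, since every step available is unreadable. The expectation for compound 4 is that this assay again reports a limit; the estimate for compound 4 is 9000 nM, spanning 3000 nM to 30000 nM. This rests on compound 3, whose value in this assay is itself a limit, > 8500 nM. The estimated step that the limit leaves unreadable from compound 3 to compound 4 is expected to stay within the scatter.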

Compound 4, half-maximal inhibitory concentration: > 7790 nM
Compound 4: a limit, no number; the forecaster's own chance of this, stated with the estimate: 85%; the middle value lies beyond the limit too.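

In this assay compound 4 gives > 7790 nM, again a limit and not a number. All four values are limits, and the steps from compound 1, compound 2 and compound 3 to compound 4 cannot be read. The compounds shown leave open whether exchanging the group on this carbon of the shared core changes the read-out at all.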